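The source may report more compounds than this note shows. Statements on the series, on what has been measured and on what is new or still open speak of the compounds shown alone.

Two compounds have been measured in a functional assay on MCF7 cells (Homo sapiens) for antiproliferative activity, read by MTT assay, with a stated time of 24 h; on this read-out lower numbers stand for stronger inhibition and higher numbers for weaker inhibition:

Compound 1 `Cc1ccc(-c2nn(-c3ccccc3)cc2-c2nc3ccccc3n2S(=O)(=O)c2cc(C)ccc2C)cc1`: 510 nM
Compound 2 `Cc1ccc(-c2nn(-c3ccccc3)cc2-c2nc3ccccc3n2S(=O)(=O)c2ccc(Cl)cc2)cc1`: 5930 nM

Compound 2 holds the higher of the two numbers, and so the weaker inhibition. Among the compounds with values here, the only measured step, a 12-fold higher number from compound 1 to compound 2 (1.07 log units; beyond the scatter), is large and puts 4-chlorophenyl in place of 2,5-dimethylphenyl on the sulfonyl sulfur. Compound 3 `Cc1ccc(-c2nn(-c3ccccc3)cc2-c2nc3ccccc3n2S(=O)(=O)c2ccc(Br)cc2)cc1` alters that same group, but far less: bromo in place of chloro on an aromatic carbon. This is bromo in place of chloro on an aromatic carbon, para to a large group. Within the data shown here, the measured step exchanged a differently substituted aryl group, and no measured pair exchanges one halogen for another, so it offers only weak guidance here. No step beyond the scatter is expected in this assay, in either direction. The estimated change is a 1.1-fold lower number from compound 2 to compound 3 (0.03 log units; within the scatter). For compound 3 the expected value is 5500 nM, with an estimated range of 2000 nM to 13000 nM.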

Compound 3, half-maximal inhibitory concentration: 3160 nM
Estimate against measurement, compound 3: 1.7-fold (0.24 log units) above; the range from low to high includes it.
By their numbers in this assay, from the lowest: compound 1; then compounds 3 and 2 (each within the scatter of the next).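

In this assay, within the data shown here, the first exchange of one halogen for another on this aryl group gives a 1.9-fold lower number from compound 2 to compound 3 (0.27 log units; within the scatter), so the two halogens cannot be told apart here. Against the 2,5-dimethylphenyl group, 4-bromophenyl gives a 6.2-fold higher number from compound 1 to compound 3 (0.79 log units; beyond the scatter), which shows that the higher number seen with 4-chlorophenyl does not depend on chloro alone, as both halogen-bearing compounds sit above compound 1. Nothing available gives a reason for these differences.

The compounds shown leave open whether the lower number of compound 1 needs both methyl groups, or whether a single methyl would give the same result. They also leave open how a 4-methoxyphenyl group or an amine-bearing aryl group on the sulfonyl sulfur would compare with these three.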